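This account rests on a few compounds, and the source may have more. Where it says the series, first, only, none or still open, it means among the compounds named here.

Compound 1 `C[C@H](NC(=O)C(=O)Nc1ccccn1)C(=O)N[C@@H](CC(=O)O)C(=O)COc1c(F)c(F)cc(F)c1F` carries the highest number of the three measured compounds in a functional assay on Jurkat cells (Homo sapiens) for inhibition (on this read-out lower numbers stand for stronger inhibition and higher numbers for weaker inhibition), where compound 1 gives 1040 nM. Compound 2 `C[C@H](NC(=O)C(=O)Nc1ccccc1F)C(=O)N[C@@H](CC(=O)O)C(=O)COc1c(F)c(F)cc(F)c1F` gives 160 nM in this assay, and compound 3 `C[C@H](NC(=O)C(=O)Nc1cc(C(C)(C)C)ccc1C(C)(C)C)C(=O)N[C@@H](CC(=O)O)C(=O)COc1c(F)c(F)cc(F)c1F` gives 62 nM. Going by the values given here, the one single-point step recorded, a 6.5-fold lower number from compound 1 to compound 2 (0.81 log units; beyond the scatter), shows that exchanging the pyridin-2-yl for a carbocyclic ring lowered the number beyond the scatter, and compound 3, with its larger carbocyclic group, sits lower still. Compound 4 `C[C@H](NC(=O)C(=O)Nc1ccccc1-c1ccc[nH]1)C(=O)N[C@@H](CC(=O)O)C(=O)COc1c(F)c(F)cc(F)c1F` changes compound 1 by 2-(1H-pyrrol-2-yl)phenyl in place of pyridin-2-yl on an amide-type nitrogen. Since the same kind of exchange gave a 6.5-fold lower number from compound 1 to compound 2 (0.81 log units; beyond the scatter), compound 4 is expected to lie below compound 1, and its step is estimated as a 6.9-fold lower number from compound 1 to compound 4 (0.84 log units; beyond the scatter). For compound 4 the estimate in this assay is 150 nM, within a range from 40 nM to 550 nM.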

Compound 4, half-maximal inhibitory concentration: 56 nM
Beside the measured number, compound 4's estimate is 2.7-fold (0.43 log units) above it, and the stated range covers the measured number.
By their numbers in this assay, from the lowest: compounds 4 and 3 (each within the scatter of the next); then compound 2; then compound 1.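

In this assay, the aromatic carbon that carries fluoro in compound 2 accepts a much larger 1H-pyrrol-2-yl group, and the number falls further (a 2.9-fold lower number from compound 2 to compound 4 (0.46 log units; beyond the scatter)). The full exchange on the amide-type nitrogen is therefore large (a 19-fold lower number from compound 1 to compound 4 (1.27 log units; beyond the scatter)), so the substituent on the phenyl ring matters, not only the replacement of pyridin-2-yl by a carbocyclic ring. No supporting data explain this gain. From the compounds shown here alone, it remains open whether the pyrrole's hydrogen-bond donor is needed, which 1-methylpyrrol-2-yl or furan-2-yl could test. An amine or carboxylic acid at that carbon is also untested here.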